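Adding a Methyl to a Glutamate Receptor Modulator

The source may hold more compounds than are shown below. What is called first, only, known or untested is meant among the compounds shown, and "the series" means these compounds.

Measured compounds:
compound 1, `O=C(Nc1ccccn1)c1cc2n(n1)CCCC2`: 364 nM
compound 2, `N#Cc1cccnc1NC(=O)c1cc2n(n1)CCCC2`: "not active" (no number reported)
compound 3, `COc1cccnc1NC(=O)c1cc2n(n1)CCCC2`: "not active" (no number reported)

All three share the same core, an amide joined to a pyridine ring, and were tested in a functional assay on HEK293 cells for negative allosteric modulation of metabotropic glutamate receptor 5 (Rattus norvegicus), read by FLIPR and calcium flux, with a stated time of 170 s; a lower number here means a stronger inhibitor, a higher number a weaker inhibitor. Among the measured compounds shown here, compound 1 is the unsubstituted parent, and in this assay compound 1 gives 364 nM, the only numerical value among the three. Compound 2 carries a nitrile on the pyridine and is reported as "not active" (no number reported). Compound 3 carries a methoxy group on the pyridine and is likewise reported as "not active" (no number reported). No numbered step between measured compounds is available, so nothing can be said about the size of these two losses beyond the fact that no number was obtained.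

Compound 4, `Cc1ccnc(NC(=O)c2cc3n(n2)CCCC3)c1`, has not yet been measured. It differs from compound 1 by methyl in place of hydrogen on an aromatic carbon. The substituents in compound 2 and compound 3 sit on a different ring carbon, so their outcome does not settle what a methyl at this place will do. A small step, within the scatter or a modest gain, is expected here. For compound 4 the expected step is a 1.5-fold lower number from compound 1 to compound 4 (0.16 log units; within the scatter). Compound 4 is therefore estimated at 250 nM, with a range from 80 nM to 900 nM.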

Compound 4, half-maximal inhibitory concentration: "not active" (no number reported)
The entry for compound 4 holds no number; no gap can be computed for the estimate.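

In this assay, among the compounds shown here, compound 4 is reported as "not active" without a number, so no step from compound 1, at 364 nM, can be read. The compounds shown leave open how large the change with the methyl is, and what other groups at this place would do. Nothing shown bears on the reason for this result.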